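A Methyl for a Fluoro on the Outer Ring

The source may hold more compounds than are shown below. What is called first, only, known or untested is meant among the compounds shown, and "the series" means these compounds.

Compound 1, `O=C(Nc1ccc(Oc2ccnc3[nH]ccc23)cc1)c1nn(-c2ccc(Br)cc2)ccc1=O`, in a functional assay on PC-3 cells (Homo sapiens) for cytotoxicity, read by MTT assay, with a stated time of 72 h (a higher number here means a weaker inhibitor, a lower number a stronger inhibitor), compound 1 gives 8040 nM.
Compound 2, `Cc1cc(=O)n(-c2ccc(F)cc2)nc1C(=O)Nc1ccc(Oc2ncnc3[nH]ccc23)cc1`, in this assay compound 2 reaches only the limit > 60000 nM.
Compound 3, `Cc1cc(=O)n(-c2ccc(F)cc2)nc1C(=O)Nc1ccc(Oc2ncnc3[nH]ccc23)c(F)c1`, in this assay compound 3 gives 17300 nM.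

Compound 3 therefore has the highest of the two numbers shown; compound 1 sits below it, and the value of compound 2 is a limit of the assay, as the limit of > 60000 nM in this assay, at which 1 of the 3 values shown sits, states. Compound 4, `Cc1ccc(-n2nc(C(=O)Nc3ccc(Oc4ncnc5[nH]ccc45)c(F)c3)c(C)cc2=O)cc1`, differs from compound 3 by methyl in place of fluoro on an aromatic carbon. For the measured compounds named here, the one measured step, an at least 3.4-fold lower number from compound 2 to compound 3 (0.54 log units; beyond the scatter), concerns a different change, so no measured step bears on this one. The step is expected to stay within the scatter, as a 1.2-fold lower number from compound 3 to compound 4 (0.06 log units; within the scatter). Compound 4 is estimated at 15000 nM, with a range from 5000 nM to 50000 nM.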

Compound 4, half-maximal inhibitory concentration: 20400 nM
Beside the measured number, compound 4's estimate is 1.4-fold (0.13 log units) below it; the range from low to high includes it.
By their numbers in this assay, from the lowest: compound 1; then compounds 3 and 4 (each within the scatter of the next). At a limit, above all of these: compound 2.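

In this assay the change from 4-fluorophenyl to 4-methylphenyl gives a 1.2-fold higher number from compound 3 to compound 4 (0.07 log units; within the scatter). For the compounds shown here, this is the first measured change at this place on the outer ring, and here fluoro and methyl cannot be told apart by their numbers. No measured information shown here bears on why the two groups read alike.

From the compounds shown here alone, it remains open whether an amine or a carboxylic acid at this place would move the number beyond the scatter. Going by these compounds, it is also open whether the bromo of compound 1 would read the same on the core of compound 3.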